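Cytotoxicity notes on four chlorophenyl isomers

The source may hold more compounds than are shown below. What is called first, only, known or untested is meant among the compounds shown, and "the series" means these compounds.

Compound 1 `O=c1[nH]cc(S(=O)(=O)Nc2cccc(-c3cn(-c4cccc(Cl)c4)nn3)c2)c(=O)[nH]1` and compound 2 `O=c1[nH]cc(S(=O)(=O)Nc2cccc(-c3cn(-c4ccc(Cl)cc4)nn3)c2)c(=O)[nH]1` share one core; compound 3 `O=c1[nH]cc(S(=O)(=O)Nc2ccc(-c3cn(-c4cccc(Cl)c4)nn3)cc2)c(=O)[nH]1` and compound 4 `O=c1[nH]cc(S(=O)(=O)Nc2ccc(-c3cn(-c4ccc(Cl)cc4)nn3)cc2)c(=O)[nH]1` share the other, and the difference between the two cores is not broken down here. In an ADME assay on L02 cells (Homo sapiens) for cytotoxicity, read by MTT assay, with a stated time of 24 h (on this read-out higher numbers stand for lower toxicity in this test and lower numbers for higher toxicity in this test), compound 1 gives 8330 nM, compound 2 gives 9860 nM and compound 3 gives 19000 nM. The change 4-chlorophenyl in place of 3-chlorophenyl on an aromatic nitrogen made a 1.2-fold higher number from compound 1 to compound 2 (0.07 log units; within the scatter). The same change, (4-chlorophenyl in place of 3-chlorophenyl on an aromatic nitrogen), leads from compound 3 to compound 4, which has not yet been measured in this assay. A step of a 1.2-fold higher number from compound 3 to compound 4 (0.06 log units; within the scatter) is expected, because the same change on the other core already gave a 1.2-fold higher number from compound 1 to compound 2 (0.07 log units; within the scatter). Compound 4 is therefore estimated at 22000 nM in this assay, with a likely range from 11000 nM to 45000 nM.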

Compound 4, half-maximal cytotoxic concentration: 42900 nM
Compound 4: the middle estimate sits 2.0-fold (0.29 log units) below what was measured; low and high end bracket the measured number.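

In this assay, 4-chlorophenyl in place of 3-chlorophenyl on the aromatic nitrogen gives a 2.3-fold higher number from compound 3 to compound 4 (0.35 log units; beyond the scatter). Set beside the step on the core of compound 1, this step cannot be told apart from it, so the change carries across these two cores without a difference that can be resolved: the same change on two cores in this assay, a 1.2-fold higher number (0.07 log units; within the scatter) from compound 1 to compound 2 and a 2.3-fold higher number (0.35 log units; beyond the scatter) from compound 3 to compound 4, 1.9-fold (0.28 log units) apart, within the scatter of two such steps. This does not show that the step has the same size on both cores, and two pairs give no rule for any other core in the series.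

Open, going by these compounds, is how a phenyl bearing an amine or a carboxylic acid in place of the chlorine would read in this assay. Also open, on these data alone, is the size of this step on any further core.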